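The compounds below may be only part of what the source reports. "The series", "measured", "known", "first", "only" and "open" are said of these compounds alone.

Of the compounds shown here, three built on a shared core have numbers so far in an ADME assay on microsomes from liver (Homo sapiens) for pharmacokinetics, read by LC-MS, with a stated time of 60 min, tested at 1 uM (on this read-out lower numbers stand for slow clearance and higher numbers for fast clearance), for comparison. Compound 1 `O=C(NCc1ccc(S(=O)(=O)C2CCCOC2)cc1)N1Cc2ccncc2C1` reads 7 mL/min/kg there, compound 2 `CCC(=O)N1CCC(S(=O)(=O)c2ccc(CNC(=O)N3Cc4ccncc4C3)cc2)CC1` reads 11 mL/min/kg there, and compound 3 `O=C(NCc1ccc(S(=O)(=O)C2CCN(C3COC3)CC2)cc1)N1Cc2ccncc2C1` reads 10 mL/min/kg on the same scale. Compound 3 therefore stands within the scatter of both others, and the three cannot be ranked. Compound 4 `O=C(NCc1ccc(S(=O)(=O)N2CCC(O)CC2)cc1)N1Cc2ccncc2C1` has not yet been measured. The structural difference is 4-hydroxypiperidin-1-yl in place of 1-(oxetan-3-yl)piperidin-4-yl on a sulfonyl sulfur and it puts 4-hydroxypiperidin-1-yl in place of 1-(oxetan-3-yl)piperidin-4-yl on a sulfonyl sulfur. Exchanging the group on that sulfur gave a 1.6-fold higher number from compound 1 to compound 2 (0.20 log units; within the scatter) and also a 1.4-fold higher number from compound 1 to compound 3 (0.15 log units; within the scatter) in these measurements. Exchanging propanoyl for oxetan-3-yl on an amine nitrogen in a ring gave a 1.1-fold lower number from compound 2 to compound 3 (0.04 log units; within the scatter) on the same read-out. All three steps lie within the scatter. Going by the values given here, no measured compound carries 4-hydroxypiperidin-1-yl, so these steps are only indirect guides. With a 1.4-fold higher number from compound 1 to compound 3 (0.15 log units; within the scatter) and a 1.1-fold lower number from compound 2 to compound 3 (0.04 log units; within the scatter) as the nearest evidence, no step beyond the scatter is expected in this assay for this change. The estimated step (a 1.1-fold lower number from compound 3 to compound 4 (0.05 log units; within the scatter)) is correspondingly small. For compound 4 the estimate is 9 mL/min/kg with an expected range from 5 mL/min/kg to 17 mL/min/kg as the likely span.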

Compound 4, clearance: 6 mL/min/kg
The estimate for compound 4 lay 1.5-fold (0.18 log units) above the measured number; low and high end bracket the measured number.
By their numbers in this assay, from the lowest: compounds 4, 1, 3 and 2 (each within the scatter of the next).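

In this assay, going by these compounds alone, 4-hydroxypiperidin-1-yl is the first group on the sulfonyl sulfur to bring a hydrogen-bond donor, and it is smaller in heavy atoms than 1-(oxetan-3-yl)piperidin-4-yl, yet the exchange gave only a 1.7-fold lower number from compound 3 to compound 4 (0.22 log units; within the scatter) and, against the other two groups, a 1.8-fold lower number from compound 2 to compound 4 (0.26 log units; within the scatter) and a 1.2-fold lower number from compound 1 to compound 4 (0.07 log units; within the scatter). The position therefore accepts a group with a donor, and one joined to the sulfur through its ring nitrogen, without any of the four compounds separating from the others, so this wider set of groups still shows no measurable dependence of the read-out on what sits at that sulfur. No supporting measurement accompanies these numbers, so the data offer no account of why the steps stay this small.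

As far as these compounds go, whether any group on that sulfur can move the number beyond the scatter remains open, for instance a carboxylic acid or a primary amine on the piperidine ring, or an open alkyl chain in place of the ring. The compounds shown also leave open whether the hydroxyl itself matters, since none carries a plain piperidin-1-yl for direct comparison with compound 4.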